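This account rests on a few compounds, and the source may have more. Where it says the series, first, only, none or still open, it means among the compounds named here.

Measured compounds:
- compound 1, `Cc1ccccc1-c1nnc(SCCn2c([N+](=O)[O-])cnc2C)o1`, with 15800 nM
- compound 2, `Cc1ncc([N+](=O)[O-])n1CCSc1nnc(-c2ccc(F)cc2)o1`, with 8100 nM
- compound 3, `Cc1ncc([N+](=O)[O-])n1CCSc1nnc(-c2ccccc2Cl)o1`, with 22500 nM

In a functional assay on MCF7 cells (Homo sapiens) for cytotoxicity, read by MTT assay, with a stated time of 48 h (a higher number here means a weaker inhibitor, a lower number a stronger inhibitor), compound 1 stands second highest of the three numbers; its nearest neighbour is compound 3, by a 1.4-fold higher number from compound 1 to compound 3 (0.15 log units; within the scatter), and its furthest is compound 2, by a 2.0-fold lower number from compound 1 to compound 2 (0.29 log units; within the scatter). Compound 4, `Cc1ncc([N+](=O)[O-])n1CCSc1nnc(-c2cccs2)o1`, has not yet been measured. It differs from compound 1 in one place: thiophen-2-yl in place of 2-methylphenyl on an aromatic carbon.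

The three measured steps all exchange the aromatic group on that same carbon of the shared core. Two of them stayed within the scatter, and only the change from compound 2 to compound 3 went beyond it, by a 2.8-fold higher number from compound 2 to compound 3 (0.44 log units; beyond the scatter), a modest step. Exchanging this group has therefore moved this assay little so far, and a thiophen-2-yl in this position is expected to behave the same way, giving no step beyond the scatter.

For compound 4 the value in this assay is estimated at 12000 nM, with a range from 5000 nM to 30000 nM, which means an expected step of a 1.3-fold lower number from compound 1 to compound 4 (0.12 log units; within the scatter).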

Compound 4, half-maximal inhibitory concentration: 25800 nM
The estimate for compound 4 lay 2.2-fold (0.33 log units) below the measured number; measured number inside the range.
By their numbers in this assay, from the lowest: compounds 2, 1, 3 and 4 (each within the scatter of the next, the first and the last beyond it).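

In this assay, replacing a six-membered aromatic ring with the five-membered, sulfur-containing thiophen-2-yl leaves compound 4 within the scatter of both compounds with an ortho-free description aside: the steps (a 1.6-fold higher number from compound 1 to compound 4 (0.21 log units; within the scatter)) and (a 1.1-fold higher number from compound 3 to compound 4 (0.06 log units; within the scatter)) are both too small to read as real changes. Among the compounds shown here, the one step beyond the scatter (a 3.2-fold higher number from compound 2 to compound 4 (0.50 log units; beyond the scatter)) starts from the 4-fluorophenyl group, yet that group is not clearly separated from 2-methylphenyl (a 2.0-fold lower number from compound 1 to compound 2 (0.29 log units; within the scatter)), so the four groups form a shallow series rather than distinct levels. Nothing measured on these compounds offers a reason for this gap.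

As far as these compounds go, all four compounds carry an aromatic ring on this carbon, so it stays open whether an amine, a carboxylic acid or a longer chain there would move the number further. From the compounds shown here alone, how much the shared core itself contributes also stays open.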